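Aryl swap on the thiophene-bearing carbon of compound 3

A few compounds are considered here, and "the series" means these few. Any claim that something is new, unique, unknown or untested is made for them only; others in the source may bear on it.

Compound 3 `CCOC(=O)c1c(N)sc(-c2cccc(C(C)=O)c2)c1-c1cccc(C(F)(F)F)c1` gives 68.9% in an assay on CHO-K1 cells for displacement of a labelled ligand from adenosine receptor A1 (Homo sapiens), tested at 10 uM; on this read-out lower numbers stand for less inhibition and higher numbers for more inhibition at the one concentration tested (going by the name of the read-out); of the three numbers it stands second highest, below compound 1 and above compound 2. Compound 1 `CCOC(=O)c1c(-c2cccc(C(F)(F)F)c2)csc1N` gives 93%, and compound 2 `Nc1sc(-c2ccc([N+](=O)[O-])cc2)c(-c2cccc(C(F)(F)F)c2)c1C(=O)c1ccccc1` gives 34.8%. The change to compound 4 `CCOC(=O)c1c(N)sc(-c2ccc([N+](=O)[O-])cc2)c1-c1cccc(C(F)(F)F)c1` is 4-nitrophenyl in place of 3-acetylphenyl on an aromatic carbon. Among the measured compounds shown here, the one measured step at this carbon is a number 24.1 percentage points lower from compound 1 to compound 3 (beyond the scatter), a modest loss on introducing the 3-acetylphenyl group. Compound 2 also carries 4-nitrophenyl on the same carbon, though its core otherwise differs, and its value sits well beneath that of compound 3. Together these suggest a further modest drop is expected, as a number 13.9 percentage points lower from compound 3 to compound 4 (beyond the scatter). Compound 4 is estimated at 55%, within 30% to 78%.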

Compound 4, a percentage reported as inhibition, at one concentration (the size of the read-out at that concentration, not a potency): 71.4%
Compound 4: the middle estimate sits 16.4 percentage points below what was measured; low and high end bracket the measured number.
By their numbers in this assay, from the lowest: compound 2; then compounds 3 and 4 (each within the scatter of the next); then compound 1.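

At this carbon, the data do not separate 4-nitrophenyl from 3-acetylphenyl (a number 2.5 percentage points higher from compound 3 to compound 4 (within the scatter)). Against hydrogen, 4-nitrophenyl gives a loss (a number 21.6 percentage points lower from compound 1 to compound 4 (beyond the scatter)) of the same order as that with 3-acetylphenyl (a number 24.1 percentage points lower from compound 1 to compound 3 (beyond the scatter)). With 4-nitrophenyl held in place, ethoxy in place of phenyl on the carbonyl carbon gives a far larger step (a number 36.6 percentage points higher from compound 2 to compound 4 (beyond the scatter)) than the aryl swap.

No supporting measurement bears on why the values fall this way. As far as these compounds go, whether an amine or a short alkyl chain on this carbon would match these two aryl groups stays open.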